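This account rests on a few compounds, and the source may have more. Where it says the series, first, only, none or still open, it means among the compounds named here.

Compound 2 `Cc1ccc(C(=O)N/N=C/c2ccccc2O)c(O)c1` was tested in a functional assay (Mus musculus, strain BALB/C) for inhibition, read by MTT assay, with stated times of 24 h and 72 h (a lower number here means a stronger inhibitor, a higher number a weaker inhibitor), where compound 2 gives 1020 nM. Among the measured compounds shown here, the only other compound measured there, compound 1 `Cc1ccc(C(=O)N/N=C/c2cc(Cl)cc(Cl)c2O)c(O)c1`, gives 1510 nM. Compound 2 thus has the lower of the two numbers, but the gap to compound 1 lies within the scatter of repeated measurements, so the two cannot be told apart on these data.

Compound 3 `Cc1ccc(C(=O)N/N=C/c2cc(Cl)ccc2O)c(O)c1` has not yet been measured. It differs from compound 2 in one place: chloro in place of hydrogen on an aromatic carbon. For the measured compounds named here, no step between measured compounds has been recorded that would show what such a change does here; the only hint is that compound 1, which also carries chloro groups, gives a number within the scatter of compound 2. On that basis compound 3 is expected to show a step of a 1.2-fold higher number from compound 2 to compound 3 (0.07 log units; within the scatter) that stays within the scatter, with no direction favoured. The estimate for compound 3 is 1200 nM, with a range from 600 nM to 2400 nM.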

Compound 3, half-maximal inhibitory concentration: 1290 nM
Beside the measured number, compound 3's estimate is 1.1-fold (0.03 log units) below it, within the range that was stated.
By their numbers in this assay, from the lowest: compounds 2, 3 and 1 (each within the scatter of the next).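

In this assay, among the compounds shown here, this is the first look at a single chloro group on its own, on the aromatic carbon para to a hydroxy group, and it gives a 1.3-fold higher number from compound 2 to compound 3 (0.10 log units; within the scatter). Compound 1 could not show this, since it differs from compound 2 in two places, whereas compound 3 splits that double change into two single ones: going back from two chloro groups to one gives a 1.2-fold lower number from compound 1 to compound 3 (0.07 log units; within the scatter), so neither chloro group, taken singly, has an effect that can be told apart from the noise of the assay on these data. Nothing available explains these small steps or shows what lies behind them.

So far the only group compared with hydrogen at this position is chloro, so it remains open whether a different kind of group there, such as an amine, a carboxylic acid or a longer chain, would shift the number beyond the scatter. From the compounds shown here alone, it is also open whether changes elsewhere on the shared core, for example at the hydroxy group itself, would matter more than this position does.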